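The source may hold more compounds than are shown below. What is called first, only, known or untested is meant among the compounds shown, and "the series" means these compounds.

Working notes on the series. Compound 1 `CC[C@@H](Nc1c(C#N)c(-c2ccc(-c3ccc(OC)cc3)cc2)nc2cnccc12)C(N)=O` and compound 2 `CCOc1ccccc1-c1ccc(-c2nc3cnccc3c(C[C@H](C)C(N)=O)c2C#N)cc1` share the core; in a physicochemical assay for lipophilicity, read by HPLC, at pH 7.5 (on this read-out higher numbers stand for higher lipophilicity and lower numbers for lower lipophilicity), compound 1 gives 2.7 and compound 2 gives 3, two values within the scatter of each other, so neither stands apart. Compound 3 `CC[C@@H](Nc1c(C#N)c(-c2ccc(-c3ccccc3OC)cc2)nc2cnccc12)C(N)=O` differs from compound 1 in one place: 2-methoxyphenyl in place of 4-methoxyphenyl on an aromatic carbon. For the measured compounds named here, no measured pair isolates this change. The same atoms joined differently rarely move this read-out, so no step beyond the scatter is expected: the estimated step of a number 0.10 log units lower from compound 1 to compound 3 (within the scatter) is small. Compound 3 is expected at 2.6 in this assay, within 2.2 to 3.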

Compound 3, distribution coefficient: 2.7
The estimate for compound 3 lay 0.10 log units below the measured number, within the range that was stated.
By their numbers in this assay, from the lowest: compounds 1, 3 and 2 (each within the scatter of the next).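

For the compounds shown here, the exchange of 4-methoxyphenyl for 2-methoxyphenyl gives no change at the digits printed from compound 1 to compound 3 (within the scatter) in this assay, and this pair is the only one that isolates a change at this position. On an aromatic carbon para to a large group, this read-out therefore does not separate these two groups, although one pair sets no wider pattern. On these data alone, whether an amine or a carboxylic acid at this place would leave the read-out equally unmoved stays open, as does whether the same exchange would read alike with the side chain of compound 2. No supporting data bear on this result.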